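Trimming the Alkyne Methyl in an Indole Series

The compounds below may be only part of what the source reports. "The series", "measured", "known", "first", "only" and "open" are said of these compounds alone.

Compound 2, `CC#CCN(C)Cc1cc2cc(O)ccc2n1C`, was measured in an assay on isolated protein for inhibition of Amine oxidase [flavin-containing] B (Rattus norvegicus) (a lower number here means a stronger inhibitor, a higher number a weaker inhibitor), and gives 8800 nM. Among the three compounds with numbers, compound 2 holds the second highest. Its nearest neighbour is compound 3, `C#CCNCc1cc2ccccc2n1C`, which in this assay gives 3830 nM; the gap between compound 2 and compound 3 lies beyond the usual scatter. At the far end stands compound 1, `c1ccc(CNCc2cn(Cc3ccccc3)c3ccccc23)cc1`, which in this assay gives 362000 nM, far above compound 2.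

The step to compound 4, `C#CCN(C)Cc1cc2cc(O)ccc2n1C`, is a single small change: hydrogen in place of methyl on a triple-bonded carbon, so the but-2-yn-1-yl arm becomes a propargyl arm while the hydroxyl and the other methyl groups stay in place. Among the compounds with values here, no measured pair traces this exact change, so its size has to be expected rather than read off. Compound 3, which also carries a propargyl arm, gives 3830 nM, a lower number than compound 2.

Compound 4 is therefore expected to give about 3500 nM, with a likely range from 1000 nM to 12000 nM. The expected step, a 2.5-fold lower number from compound 2 to compound 4 (0.40 log units; beyond the scatter), would be a modest move toward stronger inhibition, only a little beyond the scatter.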

Compound 4, inhibition constant: 820 nM
Beside the measured number, compound 4's estimate is 4.3-fold (0.63 log units) above it; the measured number lies below the stated range.
By their numbers in this assay, from the lowest: compound 4; then compound 3; then compound 2; then compound 1.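

In this assay, the change from but-2-yn-1-yl to propargyl brings an 11-fold lower number from compound 2 to compound 4 (1.03 log units; beyond the scatter), a large step that lies beyond the scatter. Within the data shown here, this is the first pair to differ in one place, so it gives the first measured size for a change on a triple-bonded carbon, with the hydroxyl and the other methyl groups held constant. The data offer no measured explanation for why removing this methyl has so large an effect.

On these data alone, whether an ethyl or a phenyl group on the triple-bonded carbon would take the number back up remains open, since only methyl and hydrogen appear there. As far as these compounds go, it is also open whether the step would keep its size with a methoxy group or an amine in place of the hydroxyl.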